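From 3-bromobenzyl to 4-fluorobenzyl: working notes

The source may report more compounds than this note shows. Statements on the series, on what has been measured and on what is new or still open speak of the compounds shown alone.

Measured in a functional assay on HepG2 cells (Homo sapiens) for inhibition, read by MTT assay, with a stated time of 48 h; a lower number here means a stronger inhibitor, a higher number a weaker inhibitor:
- compound 1 `Fc1ccccc1CSc1nnc(-c2ccncc2)n1-c1ccccc1`: > 50000 nM (a limit)
- compound 2 `Brc1cccc(CSc2nnc(-c3ccncc3)n2-c2ccccc2)c1`: 7040 nM

Going by the values given here, compound 2 holds the only true number so far, 7040 nM. Compound 1 gives only a limit, > 50000 nM.

Compound 3 `Fc1ccc(CSc2nnc(-c3ccncc3)n2-c2ccccc2)cc1` is not yet measured. The change leading to it is 4-fluorophenyl in place of 3-bromophenyl on a saturated chain carbon bound to a sulfur, with 4-fluorophenyl in place of 3-bromophenyl on a saturated chain carbon bound to a sulfur.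

Among the compounds with values here, one measured step bears on this: an at least 7.1-fold lower number from compound 1 to compound 2 (0.85 log units; beyond the scatter), beyond the scatter, where 3-bromophenyl replaced 2-fluorophenyl. Compound 3 gives up that 3-bromophenyl for another fluorinated ring, so a move to a higher number in this assay is expected, though one step is thin support. The expected step is a 3.1-fold higher number from compound 2 to compound 3 (0.49 log units; beyond the scatter). For compound 3 the estimated value is 22000 nM, with an expected range of 6000 nM to 50000 nM.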

Compound 3, half-maximal inhibitory concentration: 15600 nM
The estimate for compound 3 lay 1.4-fold (0.15 log units) above the measured number; measured number inside the range.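

In this assay, the change to 4-fluorophenyl gives a 2.2-fold higher number from compound 2 to compound 3 (0.35 log units; beyond the scatter), so 3-bromophenyl stays ahead of it at this place on a saturated chain carbon bound to a sulfur. A fluorinated ring as such does not push the number to the limit: the two fluorophenyl groups are separated by an at least 3.2-fold lower number from compound 1 to compound 3 (0.50 log units; beyond the scatter), so the placing of the fluorine on the ring matters here. The size of that separation stays open-ended, as compound 1 gives a limit and not a number: the limit of > 50000 nM in this assay, at which 1 of the 3 values shown sits.

3-bromophenyl and 4-fluorophenyl differ in both halogen and ring placing, and the compounds shown do not separate the two. Also open, going by these compounds, is how 4-bromophenyl, a phenyl ring carrying an amine or a carboxylic acid, or a longer chain on the sulfur would read.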